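A few compounds are considered here, and "the series" means these few. Any claim that something is new, unique, unknown or untested is made for them only; others in the source may bear on it.

Measured so far:
compound 1 `COc1nc(N)nc2c1c(-c1cc3ccccc3o1)cn2[C@@H]1O[C@H](CO)[C@@H](O)[C@H]1O`, > 20000 nM
compound 2 `C#Cc1cn([C@@H]2O[C@H](CO)[C@@H](O)[C@H]2O)c2ncnc(OC)c12`, 4060 nM
compound 3 `Nc1nc2c(c(-c3ccccc3)cn2[C@@H]2O[C@H](CO)[C@@H](O)[C@H]2O)c(=O)[nH]1`, > 20000 nM

Within the data shown here, in a functional assay on HCT-116 cells (Homo sapiens), read by MTT assay, with a stated time of 72 h (a lower number here means a stronger inhibitor, a higher number a weaker inhibitor), compound 2 gives the only number in the set, 4060 nM. For compound 1 the entry > 20000 nM is a limit of the assay, not a number. For compound 3 the entry > 20000 nM is likewise a limit; see (the limit of > 20000 nM in this assay, at which 2 of the 3 values shown sit). Among the measured compounds shown here, no step between measured compounds differing in one place is available, so the change to compound 4 `COc1ncnc2c1c(-c1ccccc1)cn2[C@@H]1O[C@H](CO)[C@@H](O)[C@H]1O` rests on the change itself: phenyl in place of ethynyl on an aromatic carbon. The step from compound 2 to compound 4 is expected to lie beyond the scatter, toward weaker inhibition, a 3.0-fold higher number from compound 2 to compound 4 (0.47 log units; beyond the scatter). Compound 4 is therefore estimated at 12000 nM, between 3000 nM and 40000 nM, with a fair chance that only a limit is reported.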

Compound 4, half-maximal inhibitory concentration: > 20000 nM
Compound 4: only a limit was reported; the forecaster's own chance of this, stated with the estimate: 40%; middle value at least 1.6-fold (0.22 log units) from the limit.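

Among these compounds, on the aromatic carbon two ring bonds from the ring nitrogen, phenyl in place of ethynyl gives the first readable step in this assay: an at least 4.9-fold higher number from compound 2 to compound 4 (0.69 log units; beyond the scatter). Between these two compounds, only ethynyl at this position leaves a measurable number. The step is a bound and not a size, as compound 4 rests on a limit of the assay: the limit of > 20000 nM in this assay, at which 3 of the 4 values shown sit.

On these data alone, how far compound 4 lies past that limit stays open. Also open, as far as these compounds go, is how a nitrile, an amine or a longer alkyne chain on this carbon would read.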